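Removing the Amino Group from a Purine-Like Core

The source may report more compounds than this note shows. Statements on the series, on what has been measured and on what is new or still open speak of the compounds shown alone.

Measured compounds:
Compound 1, `Nc1nc(Cl)c2ncn(Cc3ccccc3CCl)c2n1`: 15900 nM
Compound 2, `Nc1nc(Cl)c2ncn(Cc3cccc(CCl)c3)c2n1`: 21400 nM

In a functional assay on EKVX cells (Homo sapiens) for cytotoxicity, read by sulforhodamine B assay, with a stated time of 48 h (on this read-out higher numbers stand for weaker inhibition of growth and lower numbers for stronger inhibition of growth), compound 1 gives 15900 nM, and compound 2 gives 21400 nM. Compound 1 has the lowest of the two numbers, yet the gap to compound 2 is within the scatter, so the two stand together as weak inhibitors of growth.

Compound 3, `ClCc1ccccc1Cn1cnc2c(Cl)ncnc21`, has not yet been tested in this assay. It differs from compound 1 in one place: hydrogen in place of amino on an aromatic carbon. The amino group leaves from an aromatic carbon of a six-membered aromatic ring that sits between two ring nitrogen atoms, and a hydrogen enters in its stead.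

Among the measured compounds shown here, no step between measured compounds shows the effect of this change. The step of a 1.4-fold higher number from compound 1 to compound 3 (0.14 log units; within the scatter) is expected to be small, at most just beyond the scatter, toward weaker inhibition of growth. Compound 3 is therefore estimated at 22000 nM, with a range from 8000 nM to 60000 nM.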

Compound 3, concentration for 50% growth inhibition: 3090 nM
For compound 3 the middle estimate is 7.1-fold (0.85 log units) above the measured one, and the stated range ends above it.
By their numbers in this assay, from the lowest: compound 3; then compounds 1 and 2 (each within the scatter of the next).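

With hydrogen in place of amino on the aromatic carbon between two ring nitrogen atoms, this assay gives a 5.1-fold lower number from compound 1 to compound 3 (0.71 log units; beyond the scatter), so the amino group at this place is not required for growth inhibition, and its loss goes with stronger inhibition of growth. Compound 1 and compound 2 both carry the amino group, so they could say nothing about this position. No measurement shown accounts for the direction or size of this step.

The compounds shown leave open whether a methyl group or a methylamino group on this carbon would give a number closer to that of compound 3 or to that of compound 1. They also leave open whether the same replacement would give a similar step when made on compound 2.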